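From compound 2 to compound 3: one added methyl

The source may report more compounds than this note shows. Statements on the series, on what has been measured and on what is new or still open speak of the compounds shown alone.

Measured in a functional assay on A549 cells (Homo sapiens) for antiproliferative activity, read by MTT assay, with a stated time of 72 h; a lower number here means a stronger inhibitor, a higher number a weaker inhibitor:
- compound 1 `CC/C=C/C(=O)Nc1cccc(Oc2nc(Nc3ccn(C)n3)nc3c2CSCC3)c1`: 36800 nM
- compound 2 `C/C=C/C(=O)Nc1cccc(Oc2nc(Nc3ccc(OC)nc3)nc3c2CSCC3)c1`: 8040 nM

Only these two compounds have been measured so far. Compound 2 holds the lower number, 8040 nM, while compound 1 reads higher at 36800 nM, a gap beyond the usual scatter. The two differ in more than one place, so this gap cannot be assigned to any single change.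

Compound 3 `CC/C=C/C(=O)Nc1cccc(Oc2nc(Nc3ccc(OC)nc3)nc3c2CSCC3)c1` departs from compound 2 in one place only: methyl in place of hydrogen on a saturated chain carbon bound to a double-bonded chain carbon. This is methyl in place of hydrogen on a saturated chain carbon bound to a double-bonded chain carbon, so that prop-1-en-1-yl becomes but-1-en-1-yl. Within the data shown here, no measured pair isolates this change. Compound 1 already carries but-1-en-1-yl and reads 36800 nM, which gives only a weak hint towards a higher number. In this assay, the expected result is therefore no shift beyond the scatter. The expected step is a 1.2-fold higher number from compound 2 to compound 3 (0.07 log units; within the scatter), which would stay within the scatter. Compound 3 is estimated at 9500 nM, with an expected range of 4000 nM to 22000 nM.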

Compound 3, half-maximal inhibitory concentration: 13100 nM
Compound 3: middle estimate off by 1.4-fold (0.14 log units), on the low side; the measured number falls inside the stated range.
By their numbers in this assay, from the lowest: compounds 2 and 3 (each within the scatter of the next); then compound 1.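

In this assay, among these compounds, the added methyl on a saturated chain carbon bound to a double-bonded chain carbon, which turns prop-1-en-1-yl into but-1-en-1-yl, gives a 1.6-fold higher number from compound 2 to compound 3 (0.21 log units; within the scatter) and so is isolated here for the first time, with no shift that can be told from the scatter. Compound 3 also gives the pair that isolates the other difference in the series: with but-1-en-1-yl held in place, 6-methoxypyridin-3-yl in place of 1-methyl-1H-pyrazol-3-yl on a nitrogen on an aromatic ring gives a 2.8-fold lower number from compound 1 to compound 3 (0.45 log units; beyond the scatter) and is the only one of the two single changes that reaches beyond the scatter. Nothing at hand accounts for the size of either step.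

The compounds shown leave open whether a longer chain such as pent-1-en-1-yl, or a dimethylamino group at the end of the chain, would stay within the scatter of compound 2 and compound 3. They also leave open how a plain phenyl or a pyrimidine group on that same nitrogen would compare with 6-methoxypyridin-3-yl.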